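A few compounds are considered here, and "the series" means these few. Any claim that something is new, unique, unknown or untested is made for them only; others in the source may bear on it.

Measured compounds:
- compound 1 `c1ccc(-c2cn3ccnc3c(-c3ccc4ncn(C5CCCCC5)c4c3)n2)cc1`, in a functional assay on HCT-116 cells (Homo sapiens) for inhibition, read by sulforhodamine B assay, with a stated time of 48 h, tested at 10 uM (a lower number here means less inhibition, a higher number more inhibition at the concentration tested (going by the name of the read-out)), compound 1 gives 59.5%
- compound 2 `COc1ccccc1-c1cn2ccnc2c(-c2ccc3ncn(C4CCCCC4)c3c2)n1`, in this assay compound 2 gives 28.3%

Compound 1 stands highest of the two numbers measured in this assay; the nearest is compound 2, reached by the step of a number 31.2 percentage points lower from compound 1 to compound 2 (beyond the scatter), a methoxy in place of hydrogen on an aromatic carbon.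

The unmeasured compound is compound 3 `Fc1ccccc1-c1cn2ccnc2c(-c2ccc3ncn(C4CCCCC4)c3c2)n1`. It differs from compound 1 as follows: fluoro in place of hydrogen on an aromatic carbon

For the measured compounds named here, only one measured step bears on this change: a number 31.2 percentage points lower from compound 1 to compound 2 (beyond the scatter), which puts a methoxy on the same aromatic carbon where compound 3 carries the fluoro. That step is large and beyond the scatter. A fluoro is a different group from a methoxy, so the size of its effect is not read directly from this one step, but the direction suggested is downward. For compound 3 a downward step is therefore expected in this assay, smaller than that to compound 2, namely a number 17.5 percentage points lower from compound 1 to compound 3 (beyond the scatter). In this assay compound 3 is estimated at 42%, with a range from 18% to 66%.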

Compound 3, a percentage reported as inhibition, at one concentration (the size of the read-out at that concentration, not a potency): 25.8%
Estimate against measurement, compound 3: 16.2 percentage points above, within the range that was stated.
By their numbers in this assay, from the lowest: compounds 3 and 2 (each within the scatter of the next); then compound 1.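

In this assay, fluoro in place of hydrogen on this aromatic carbon, ortho to a large group, gives a number 33.7 percentage points lower from compound 1 to compound 3 (beyond the scatter), so the loss seen with the methoxy is no longer confined to that one substituent: both groups tried on this carbon lie well under the unsubstituted phenyl of compound 1. Exchanging one group for the other gives a number 2.5 percentage points lower from compound 2 to compound 3 (within the scatter), so within this pair the reading does not separate fluoro from methoxy, and phenyl to 2-fluorophenyl is as costly a change here as the methoxy one. Nothing at hand explains why the two groups read alike or why either one lowers the number.

Still open, as far as these compounds go, is whether an amine, a hydroxyl or a chloro on this same carbon would fall with compound 2 and compound 3 or stay near compound 1, and whether fluoro on another carbon of that ring would give a similar step. From the compounds shown here alone, all three readings in this assay come from a single concentration, so how the compounds rank in potency also remains open.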